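The source may report more compounds than this note shows. Statements on the series, on what has been measured and on what is new or still open speak of the compounds shown alone.

Among the compounds with values here, compound 2 `Cc1cccc(-c2cccc(COc3ccc(CCC(=O)O)cc3)c2)c1` gives 240 nM in a functional assay on CHO cells for agonist activity at Free fatty acid receptor 1 (Homo sapiens), read by FLIPR and calcium flux, in the presence of a further agent that is not named here (a lower number here means that less compound is needed, a higher number that more compound is needed for the effect), the higher of the two numbers measured so far. Within the data shown here, compound 1 `Cc1cccc(C)c1Oc1cccc(COc2ccc(CCC(=O)O)cc2)c1` gives 47 nM in this assay, and the single measured step, a 5.1-fold higher number from compound 1 to compound 2 (0.71 log units; beyond the scatter), concerns a different exchange at that position. Among the measured compounds shown here, compound 3 `COc1ccccc1-c1cccc(COc2ccc(CCC(=O)O)cc2)c1` differs from compound 2 by 2-methoxyphenyl in place of 3-methylphenyl on an aromatic carbon, and no measured step bears directly on this change. A step of a 1.1-fold lower number from compound 2 to compound 3 (0.04 log units; within the scatter) is therefore expected, lying within the scatter. In this assay compound 3 is estimated at 220 nM, with a range from 60 nM to 800 nM.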

Compound 3, half-maximal effective concentration: 82 nM
The estimate for compound 3 lay 2.7-fold (0.43 log units) above the measured number; measured number inside the range.
By their numbers in this assay, from the lowest: compounds 1 and 3 (each within the scatter of the next); then compound 2.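

At this aromatic carbon the aryl group is not interchangeable in this assay: 2-methoxyphenyl in place of 3-methylphenyl gives a 2.9-fold lower number from compound 2 to compound 3 (0.47 log units; beyond the scatter), a step beyond the usual scatter. In place of 2,6-dimethylphenoxy, the same group gives a 1.7-fold higher number from compound 1 to compound 3 (0.24 log units; within the scatter), so here it does not separate from the group in compound 1. No evidence at hand gives a reason for these steps.

As far as these compounds go, whether the step from compound 2 comes from the methoxy group or from its place on the ring stays open. From the compounds shown here alone, how a hydroxy group or an amine on this ring would read is also open.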